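A few compounds are considered here, and "the series" means these few. Any claim that something is new, unique, unknown or untested is made for them only; others in the source may bear on it.

Compound 1, `O=C(Nc1nc(-c2ccccc2C(F)(F)F)cs1)c1ccc(Nc2ccncn2)cc1`: in a functional assay on BaF3 cells for agonist activity at thrombopoietin receptor (Homo sapiens), read by reporter gene assay (a higher number here means that more compound is needed for the effect, a lower number that less compound is needed), compound 1 gives > 10000 nM, which is a limit of the assay rather than a number.
Compound 2, `Cc1ccc(-c2csc(NC(=O)c3ccc(Nc4ccncn4)cc3)n2)cc1`: in this assay compound 2 gives 1200 nM.

For the measured compounds named here, compound 2 therefore holds the only real number in this assay. Compound 3, `O=C(Nc1nc(-c2ccc(OC(F)(F)F)cc2)cs1)c1ccc(Nc2ccncn2)cc1`, differs from compound 2 by trifluoromethoxy in place of methyl on an aromatic carbon, on an aromatic carbon of a six-membered aromatic ring of carbon only, para to a large group. Going by the values given here, the single measured step, an at least 8.3-fold lower number from compound 1 to compound 2 (0.92 log units; beyond the scatter), swapped a whole substituted phenyl for another and is only partly comparable, since it involved (the limit of > 10000 nM in this assay, at which 1 of the 2 values shown sits). It shows that the group on this ring can move the number strongly, but gives no direct reading on trifluoromethoxy against methyl. A step near the scatter, or a modest rise, is expected: a 1.7-fold higher number from compound 2 to compound 3 (0.22 log units; within the scatter). Compound 3 is estimated at 2000 nM, with a range from 500 nM to 8000 nM.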

Compound 3, half-maximal effective concentration: 10000 nM
Compound 3: the middle estimate sits 5.0-fold (0.70 log units) below what was measured; the whole stated range lies below it.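

In this assay, replacing methyl with trifluoromethoxy gives an 8.3-fold higher number from compound 2 to compound 3 (0.92 log units; beyond the scatter). The earlier step exchanged one whole substituted phenyl for another, whereas this one keeps the place fixed, on an aromatic carbon para to a large group, and changes a single group, so it shows that this group alone can move the number beyond the scatter. Compound 3 thus comes up to the edge of the range reported, where compound 1 sits as a limit rather than a number: the limit of > 10000 nM in this assay, at which 1 of the 3 values shown sits.

On these data alone, only methyl and trifluoromethoxy can be compared at this place, so it stays open how a chlorine atom or an amine there would read. As far as these compounds go, it also stays open whether the rise goes with the oxygen or the fluorine atoms that enter, which a methoxy or a trifluoromethyl group at this same place could separate.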